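The source may report more compounds than this note shows. Statements on the series, on what has been measured and on what is new or still open speak of the compounds shown alone.

Measured compounds:
- compound 1 `CCOC(=O)c1c(CN(CC)Cc2ccccc2)nc2ccccc2c1-c1ccccc1`: in an assay on brain with Translocator protein (Rattus norvegicus) as the target (on this read-out higher numbers stand for weaker inhibition and lower numbers for stronger inhibition), compound 1 gives 700 nM
- compound 3 `CCOC(=O)c1c(CN2CCc3ccccc3C2)nc2ccccc2c1-c1ccccc1`: in this assay compound 3 gives 1190 nM
- compound 2 `CCN(Cc1ccccc1)Cc1ccccc1C(=O)N(C)c1ccccc1`: in this assay compound 2 reaches only the limit of the assay, > 10000 nM, and no number is known for it.

Compound 1 stands at the lowest of the two numbers shown in this assay, with compound 3 as its nearest neighbour. Among the compounds with values here, the one measured step between the two, a 1.7-fold higher number from compound 1 to compound 3 (0.23 log units; within the scatter), is within the scatter and concerns the amine carried on the saturated chain carbon of the core, not the ester. Within the data shown here, the limit of > 10000 nM in this assay, at which 1 of the 3 values shown sits, belongs to compound 2 and gives no step at all.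

Compound 4 `CCCNC(=O)c1c(CN(CC)Cc2ccccc2)nc2ccccc2c1-c1ccccc1` differs from compound 1 in a different place: propylamino in place of ethoxy on a carbonyl carbon. No measured step in this assay touches the ethoxycarbonyl group, so the change from ethoxycarbonyl to propylcarbamoyl has no direct precedent among these compounds, and the expectation rests only on compound 1 itself. The step is therefore expected to be small, a 1.6-fold lower number from compound 1 to compound 4 (0.19 log units; within the scatter), with wide uncertainty in either direction. For compound 4 the estimate in this assay is 450 nM, in a range from 80 nM to 2500 nM.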

Compound 4, half-maximal inhibitory concentration: 872 nM
The estimate for compound 4 lay 1.9-fold (0.29 log units) below the measured number; the range from low to high includes it.
By their numbers in this assay, from the lowest: compounds 1, 4 and 3 (each within the scatter of the next). At a limit, above all of these: compound 2.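

In this assay, within the data shown here, replacing ethoxy with propylamino on the carbonyl carbon gives a 1.2-fold higher number from compound 1 to compound 4 (0.10 log units; within the scatter), the first measured step at this part of compound 1, and it lies within the usual variation between repeated measurements. For this one pair, then, the ester and the amide read alike, even though propylamino is the larger group and brings a hydrogen-bond donor that ethoxy lacks, so this position accepts the move from ethoxycarbonyl to propylcarbamoyl without a difference that this read-out can resolve. Nothing among the data shown explains why these two groups read alike.

As far as these compounds go, a single pair cannot show how far this holds, so it remains open whether a carboxylic acid, a much longer chain on the amide nitrogen or an amide without the amide hydrogen, such as a dimethylamide, would also read like compound 1 on the carbonyl carbon. From the compounds shown here alone, it is also open whether propylcarbamoyl behaves the same way when the benzyl(ethyl)amino group is replaced by 1,2,3,4-tetrahydroisoquinolin-2-yl, the group carried by compound 3.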